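Trimming the biaryl of compound 1 to a single bromine

The source may hold more compounds than are shown below. What is called first, only, known or untested is meant among the compounds shown, and "the series" means these compounds.

Measured compounds:
compound 1, `COc1ccccc1-c1cccc(S(=O)(=O)N2CCC(N3CCC(C)CC3)CC2)c1`: 21 nM
compound 2, `Cc1cc(C)c(S(=O)(=O)N2CCN(C3CCN(C)CC3)CC2)c(C)c1`: 426 nM

Of the compounds shown here, two have been tested in a functional assay on DLD-1 cells (Homo sapiens) for antiproliferative activity, read by CellTiter-Glo, with a stated time of 72 h; a higher number here means a weaker inhibitor, a lower number a stronger inhibitor. Compound 1, `COc1ccccc1-c1cccc(S(=O)(=O)N2CCC(N3CCC(C)CC3)CC2)c1`, gives 21 nM in this assay and holds the lower of the two numbers. Compound 2, `Cc1cc(C)c(S(=O)(=O)N2CCN(C3CCN(C)CC3)CC2)c(C)c1`, gives 426 nM in this assay, a far higher number, and the gap between compound 2 and compound 1 lies well beyond the usual scatter. The two share the sulfonamide and the methylated saturated amine on the far side, but differ in both the aryl portion and the central ring, so their gap cannot be tied to one change.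

Compound 3, `CC1CCN(C2CCN(S(=O)(=O)c3cccc(Br)c3)CC2)CC1`, is not yet measured. It differs from compound 1 in one place: bromo in place of 2-methoxyphenyl on an aromatic carbon. The large aryl group is thus removed and a single atom takes its place. Among the measured compounds shown here, no step between measured compounds shows this change directly, so the size of the effect is uncertain. A weakening in this assay is expected, of a size reaching beyond the scatter, with the step from compound 1 to compound 3 estimated as a 7.1-fold higher number from compound 1 to compound 3 (0.85 log units; beyond the scatter). Compound 3 is expected to give about 150 nM, within a range from 40 nM to 600 nM.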

Compound 3, half-maximal inhibitory concentration: 3.2 nM
Compound 3: middle estimate off by 47-fold (1.67 log units), on the high side; measured number outside the range, below it.
By their numbers in this assay, from the lowest: compound 3; then compound 1; then compound 2.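

In this assay, putting bromo in place of the 2-methoxyphenyl on this aromatic carbon gives a 6.6-fold lower number from compound 1 to compound 3 (0.82 log units; beyond the scatter), a change beyond the scatter and in the direction of a stronger inhibitor. The 2-methoxyphenyl, with its six-membered aromatic ring and its hydrogen-bond acceptor, is therefore not required at this position for low-nanomolar antiproliferative activity, and a single bromine atom on the same carbon does better in this pair, though one pair cannot establish a general trend. Nothing available explains why the much smaller group gives the lower number.

Going by these compounds, with a single pair at this position, it remains open whether bromine itself matters or whether chlorine, a methyl group, a nitrile or plain hydrogen on the same carbon would give a similar number. On these data alone, it is also open how an unsubstituted phenyl group would stand there, a comparison that would separate the effect of losing the methoxy group from that of losing the whole aromatic ring.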